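What one chloro might do to compound 3

The compounds below may be only part of what the source reports. "The series", "measured", "known", "first", "only" and "open" are said of these compounds alone.

Three compounds have values so far in a functional assay on A549 cells (Homo sapiens) for antiproliferative activity, read by MTT assay, with a stated time of 48 h (a higher number here means a weaker inhibitor, a lower number a stronger inhibitor), as follows:
Compound 1 (`Cc1ccc(-c2nn(-c3ccccc3)cc2C(Nc2nc3cc(C)c(C)cc3s2)c2c(O)ccc3ccccc23)cc1`) gives 31200 nM
Compound 2 (`Cc1cc2nc(NC(c3cn(-c4ccccc4)nc3-c3ccc([N+](=O)[O-])cc3)c3c(O)ccc4ccccc34)sc2cc1C`) gives 41900 nM
Compound 3 (`Oc1ccc2ccccc2c1C(Nc1nc2ccccc2s1)c1cn(-c2ccccc2)nc1-c1ccccc1`) gives 36200 nM

Compound 3 lies within the scatter of both compound 1 and compound 2, so these three numbers cannot be told apart. That makes compound 3 a plain starting point for a single change.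

The unmeasured compound 4 (`Oc1ccc2ccccc2c1C(Nc1nc2ccccc2s1)c1cn(-c2ccccc2)nc1-c1cccc(Cl)c1`) differs from compound 3 in one place (chloro in place of hydrogen on an aromatic carbon). This is chloro in place of hydrogen on an aromatic carbon, or phenyl to 3-chlorophenyl.

For the measured compounds named here, only one step between measured compounds bears on this. It also swaps a group on an aromatic carbon, here nitro in place of methyl (a 1.3-fold higher number from compound 1 to compound 2 (0.13 log units; within the scatter)), and it stayed within the scatter. Going by the values given here, no measured compound carries a chloro, so this guide is weak. Even so, nothing in the data points to a change beyond the scatter, in either direction, in this assay for this swap.

The expected step is small (a 1.1-fold lower number from compound 3 to compound 4 (0.04 log units; within the scatter)).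

Compound 4 is estimated at 33000 nM (expected range 16000 nM to 65000 nM).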

Compound 4, half-maximal inhibitory concentration: 20400 nM
Estimate against measurement, compound 4: 1.6-fold (0.21 log units) above; the range from low to high includes it.
By their numbers in this assay, from the lowest: compounds 4, 1, 3 and 2 (each within the scatter of the next, the first and the last beyond it).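

In this assay, phenyl to 3-chlorophenyl gives a 1.8-fold lower number from compound 3 to compound 4 (0.25 log units; within the scatter) on the shared core, so this single added atom leaves the two compounds indistinguishable in this test. For the compounds shown here, this is the first direct reading for a chloro, and the first for a change at this aromatic carbon on the unsubstituted benzothiazole-bearing series of compound 3, whereas the earlier step concerned only nitro in place of methyl on a different pair. Nothing measured alongside these values offers an explanation for the result, and none should be inferred from the number alone.

On these data alone, a single chloro at a single place is a narrow test, so it remains open whether a fluoro, a methoxy or an amine on this same carbon would also stay within the scatter of compound 3, or whether a chloro on another carbon of that ring would do so. As far as these compounds go, it is also open whether the same swap would read alike on the core of compound 1, which carries two extra methyl groups.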